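Swapping a carboxy for a methyl ester in a cytotoxic series

The source may hold more compounds than are shown below. What is called first, only, known or untested is meant among the compounds shown, and "the series" means these compounds.

Of the compounds shown here, three of this set have been measured in a functional assay on SK-OV-3 cells (Homo sapiens) for inhibition, read by CCK-8 assay, with a stated time of 70 h; a higher number here means a weaker inhibitor, a lower number a stronger inhibitor. Compound 1 `Clc1ccc(COc2ccc(OCCOCCNC3CCCC3)cc2)cc1` gives 7670 nM. Compound 2 `O=[N+]([O-])c1ccc(COc2ccc(OCCOCCNC3CCCC3)cc2)cc1` gives 20300 nM in this assay. Compound 3 `O=C(O)c1ccc(COc2ccc(OCCOCCNC3CCCC3)cc2)cc1` reaches only a limit of this assay, > 100000 nM, so no number is known for it. The steps among the three run a 2.6-fold higher number from compound 1 to compound 2 (0.42 log units; beyond the scatter), an at least 13-fold higher number from compound 1 to compound 3 (1.11 log units; beyond the scatter) and an at least 4.9-fold higher number from compound 2 to compound 3 (0.69 log units; beyond the scatter); with the limit of > 100000 nM in this assay, at which 1 of the 3 values shown sits, compound 3 stands at the weak end of the three, beyond the scatter from both others.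

Compound 4 `COC(=O)c1ccccc1COc1ccc(OCCOCCNC2CCCC2)cc1` is not yet measured in this assay. It differs from compound 3 in one place: 2-(methoxycarbonyl)phenyl in place of 4-carboxyphenyl on a saturated chain carbon bound to an oxygen on an aromatic ring. The carboxy group leaves, and the entering 2-(methoxycarbonyl)phenyl has no hydrogen-bond donor.

Among the compounds with values here, the steps that bear on this change are those that brought carboxy in, an at least 13-fold higher number from compound 1 to compound 3 (1.11 log units; beyond the scatter) and an at least 4.9-fold higher number from compound 2 to compound 3 (0.69 log units; beyond the scatter), both beyond the scatter and both toward weaker inhibition. Taking carboxy out again is expected to undo part of that loss, though the entering group has no measured counterpart here. The expected step is an at least 4.0-fold lower number from compound 3 to compound 4 (0.60 log units; beyond the scatter). Compound 4 is therefore estimated at 25000 nM, within 6000 nM to 100000 nM.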

Compound 4, half-maximal inhibitory concentration: > 100000 nM
Compound 4 ended at the assay's limit (the forecaster's own chance of this, stated with the estimate: 30%); middle value at least 4.0-fold (0.60 log units) away from the limit.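

Taking out the carboxy group did not bring a readable value back in this assay: compound 4, whose entering 2-(methoxycarbonyl)phenyl has no hydrogen-bond donor, ends at the limit of the assay, which is a limit and not a number. On a saturated chain carbon bound to an oxygen on an aromatic ring, a weak result therefore does not depend on a carboxy group, and the new group separates clearly from the two readable ones, with an at least 4.9-fold higher number from compound 2 to compound 4 (0.69 log units; beyond the scatter) and an at least 13-fold higher number from compound 1 to compound 4 (1.11 log units; beyond the scatter) both beyond the scatter. The step between compound 3 and compound 4 cannot be read, and no order can be given for these two, since each stands at the limit: the limit of > 100000 nM in this assay, at which 2 of the 4 values shown sit.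

The compounds shown leave open whether the methoxycarbonyl group itself or its place on the phenyl ring goes with this result, since 2-(methoxycarbonyl)phenyl differs from 4-carboxyphenyl in both respects. They also leave open how a primary amide or a hydroxymethyl group on the same ring would read in this assay, and how far compound 3 and compound 4 lie beyond the limit.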